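The source may hold more compounds than are shown below. What is called first, only, known or untested is meant among the compounds shown, and "the series" means these compounds.

In a functional assay (mast cells) for inhibition, with Rattus norvegicus as the target (a higher number here means that more compound is needed for the effect, a lower number that less compound is needed), compound 1 `CC1CC/C(=N\Nc2ccc(Br)cc2)c2ncc(C(=O)O)c(=O)n21` gives 2000 nM, while compound 2 `CCOc1ccc(N/N=C2\CCC(C)n3c2ncc(C(=O)O)c3=O)cc1` stands higher of the two at 17600 nM. Compound 3 `CC1CC/C(=N\Nc2ccc([N+](=O)[O-])cc2)c2ncc(C(=O)O)c(=O)n21` has not yet been measured. It carries nitro in place of ethoxy on an aromatic carbon, para to a large group: nitro in place of ethoxy on an aromatic carbon. Among the compounds with values here, only one measured step bears on this change: an 8.8-fold higher number from compound 1 to compound 2 (0.94 log units; beyond the scatter), with ethoxy in place of bromo at the same place. Nitro itself is untested, but losing ethoxy is expected to bring a modest move to a lower number in this assay. The estimated step is a 5.0-fold lower number from compound 2 to compound 3 (0.70 log units; beyond the scatter). The estimated value for compound 3 is 3500 nM, with an expected range of 900 nM to 14000 nM.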

Compound 3, half-maximal effective concentration: 8900 nM
Beside the measured number, compound 3's estimate is 2.5-fold (0.41 log units) below it; the measured number falls inside the stated range.
By their numbers in this assay, from the lowest: compound 1; then compounds 3 and 2 (each within the scatter of the next).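

In this assay, nitro and ethoxy at this place, para to a large group, cannot be told apart: a 2.0-fold lower number from compound 2 to compound 3 (0.30 log units; within the scatter). Bromo now stands apart from nitro as well as from ethoxy, with a 4.5-fold higher number from compound 1 to compound 3 (0.65 log units; beyond the scatter), so compound 1 has the lowest number of the three. Nothing available explains this difference. From the compounds shown here alone, whether that lowest number belongs to bromo alone stays open. Chloro, an amine or a carboxylic acid on the same aromatic carbon would show how far it extends.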